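The source may hold more compounds than are shown below. What is called first, only, known or untested is meant among the compounds shown, and "the series" means these compounds.

Compound 1 `Cc1ccc(-c2ccnc(C(=O)Nc3ccc(Oc4ccnc5[nH]ccc45)cc3)n2)cc1` gives 6140 nM.
Compound 2 `O=C(Nc1ccc(Oc2ccnc3[nH]ccc23)cc1)c1nccc(-c2cccc(Cl)c2)n1` gives 7800 nM.
Compound 3 `O=C(Nc1ccc(Oc2ccnc3[nH]ccc23)cc1)c1nccc(-c2ccc(Cl)cc2)n1` is reported as "not active" (no number reported), with no number.

The three measured compounds share one core and differ only in the substituent on the pendant phenyl ring. In a functional assay on PC-3 cells (Homo sapiens) for cytotoxicity, read by MTT assay, with a stated time of 72 h (a lower number here means a stronger inhibitor, a higher number a weaker inhibitor), compound 1 gives 6140 nM, and compound 2 gives 7800 nM; the step of a 1.3-fold higher number from compound 1 to compound 2 (0.10 log units; within the scatter) shows that changing the substituent on this ring moved the result very little. Compound 3, carrying a 4-chlorophenyl group, was reported as "not active" (no number reported) in this assay, so no number stands for it and it cannot be placed on the same scale as compound 1 or compound 2, beyond being at least as weak as both.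

Compound 4 `O=C(Nc1ccc(Oc2ccnc3[nH]ccc23)cc1)c1nccc(-c2ccc(F)cc2)n1` is the next step: fluoro in place of chloro on an aromatic carbon. Among the measured compounds shown here, only one measured step bears on a substituent change at this ring, the small one from compound 1 to compound 2, and it involved a different position, so it offers little guidance here. Compound 3 itself gives no number to step from. The expectation is therefore that compound 4 stays weak in this assay, close to where compound 1 and compound 2 lie or beyond, with a real chance that only a limit is reported. Compound 4 is estimated at 15000 nM, within a range of 5000 nM to 50000 nM.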

Compound 4, half-maximal inhibitory concentration: "not active" (no number reported)
The entry for compound 4 holds no number; the estimate stays without a comparison.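

Compound 3 and compound 4 are both reported as "not active" in this assay and carry no number, so no step can be read between them. No measurement shown here offers an explanation for this result. On these data alone, what stays open is how weak compound 3 and compound 4 truly are.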